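The source may hold more compounds than are shown below. What is called first, only, known or untested is meant among the compounds shown, and "the series" means these compounds.

Working notes on the series. Compound 1 `CN1CCN(c2ccc(Nc3nc(-c4cccc(NC(=O)c5ccc(C(F)(F)F)cc5)c4)sc3C(N)=O)cc2)CC1` carries a 4-(trifluoromethyl)phenyl on the carbonyl carbon of the amide; in a functional assay on Raji cells (Homo sapiens) for antiproliferative activity, read by CCK-8 assay, with a stated time of 72 h (on this read-out lower numbers stand for stronger inhibition and higher numbers for weaker inhibition), compound 1 gives 3210 nM. Compound 2 `CN1CCN(c2ccc(Nc3nc(-c4cccc(NC(=O)c5cccc(F)c5)c4)sc3C(N)=O)cc2)CC1` carries a 3-fluorophenyl at the same carbonyl carbon; in this assay compound 2 gives "not determined" (no result reported), so it adds nothing to the comparison. Compound 3 `CN1CCN(c2ccc(Nc3nc(-c4cccc(NC(=O)c5ccccc5F)c4)sc3C(N)=O)cc2)CC1` carries a 2-fluorophenyl there; in this assay compound 3 gives 3270 nM. On the two numbers available, compound 3 stands with the higher one, but its nearest neighbour is compound 1 and the step of a 1.0-fold higher number from compound 1 to compound 3 (0.01 log units; within the scatter) lies within the scatter, so the two cannot be ordered.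

Compound 4 `CN1CCN(c2ccc(Nc3nc(-c4cccc(NC(=O)c5ccc(Cl)cc5)c4)sc3C(N)=O)cc2)CC1` is the next member, not yet measured. The change from compound 3 is 4-chlorophenyl in place of 2-fluorophenyl on a carbonyl carbon. Going by the values given here, only one measured step bears on it: exchanging the aryl group on this carbonyl carbon between compound 1 and compound 3 left the number where it was, as the step of a 1.0-fold higher number from compound 1 to compound 3 (0.01 log units; within the scatter) shows. A further exchange of the same kind is therefore expected to give no step beyond the scatter in this assay, and the expected step of a 1.0-fold higher number from compound 3 to compound 4 (0.00 log units; within the scatter) is set accordingly. For compound 4 the estimate in this assay is 3300 nM, with a range from 1500 nM to 7500 nM.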

Compound 4, half-maximal inhibitory concentration: 5700 nM
Compound 4: the middle estimate sits 1.7-fold (0.24 log units) below what was measured; the range from low to high includes it.
By their numbers in this assay, from the lowest: compounds 1, 3 and 4 (each within the scatter of the next).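

In this assay, the step of a 1.7-fold higher number from compound 3 to compound 4 (0.24 log units; within the scatter) lies within the scatter, and the step of a 1.8-fold higher number from compound 1 to compound 4 (0.25 log units; within the scatter) does as well, so a chlorine-bearing aryl group on this carbonyl carbon shows no separable difference from either earlier group. The 2-fluorophenyl, 4-(trifluoromethyl)phenyl and 4-chlorophenyl compounds therefore cannot be ordered, and the indifference of this position, which earlier rested on a single pair, now rests on three compounds. No measurement is available that could explain these numbers.

Any steps to or from compound 2 cannot be read, so the 3-fluorophenyl group remains unplaced among the others. The compounds shown carry only halogen or trifluoromethyl substituents on a phenyl group at this carbonyl carbon, which leaves open whether an amine, a carboxylic acid or a longer alkyl chain on that ring, or a saturated cyclohexyl group in place of the phenyl, would give a step beyond the scatter in this assay.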